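Swapping a dichlorophenyl for a methylsulfanylphenyl at the limit

The compounds below may be only part of what the source reports. "The series", "measured", "known", "first", "only" and "open" are said of these compounds alone.

Values in a functional assay on A549 cells (Homo sapiens) for antiproliferative activity, read by MTT assay, with a stated time of 72 h (on this read-out higher numbers stand for weaker inhibition and lower numbers for stronger inhibition), are as follows.
Compound 1 `COc1cc(-c2ncnn2-c2cccc(N)c2)cc(OC)c1OC` gives > 10000 nM as a limit.
Compound 2 `COc1cc(-c2ncnn2-c2ccc([N+](=O)[O-])cc2)cc(OC)c1OC` gives > 10000 nM as a limit.
Compound 3 `COc1cc(-n2ncnc2-c2ccc(Cl)c(Cl)c2)cc(OC)c1OC` gives > 10000 nM as a limit.

Compound 3 therefore has no exact number in this assay and stands at the same limit as the other two compounds (the limit of > 10000 nM in this assay, at which 3 of the 3 values shown sit) so the three cannot be ranked. Compound 4 `COc1cc(-n2ncnc2-c2ccc(SC)cc2)cc(OC)c1OC` keeps the core of compound 3 and differs in one place (4-(methylsulfanyl)phenyl in place of 3,4-dichlorophenyl on an aromatic carbon) with 4-(methylsulfanyl)phenyl in place of 3,4-dichlorophenyl on an aromatic carbon. Within the data shown here, no measured pair shows the effect of a single change in this assay so any expectation here is loose. A moderate step towards stronger inhibition is expected, while another limit is about as likely as a number. The estimate implies an at least 2.5-fold lower number from compound 3 to compound 4 (0.39 log units; beyond the scatter) as the expected change. For compound 4 the estimated value is 4000 nM with an expected range from 150 nM to 20000 nM in this assay as the closing expectation.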

Compound 4, half-maximal inhibitory concentration: 800 nM
For compound 4 the middle estimate is 5.0-fold (0.70 log units) above the measured one; the range from low to high includes it.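

In this assay, compound 4 is the only one of the four compounds shown with an exact number, so the aromatic carbon between two ring nitrogen atoms is a place where the attached group can decide whether a measurable value appears. Putting 4-(methylsulfanyl)phenyl in place of 3,4-dichlorophenyl there gives an at least 12-fold lower number from compound 3 to compound 4 (1.09 log units; beyond the scatter). The full size of this step stays open, since its starting value is only a limit: the limit of > 10000 nM in this assay, at which 3 of the 4 values shown sit.

The single swap removes both chlorine atoms and brings in the methylsulfanyl group together, so the compounds shown do not separate the two effects. As far as these compounds go, whether the sulfur atom is needed also remains open, as does how a 4-methoxyphenyl, a 4-chlorophenyl or a longer chain such as 4-(ethylsulfanyl)phenyl would fare at this place.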